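Anilide to benzylamide at the amide nitrogen

The source may hold more compounds than are shown below. What is called first, only, known or untested is meant among the compounds shown, and "the series" means these compounds.

Compound 2 `CC1=C(/C=C/C(C)=C/C=C/C(C)=C\C(=O)Nc2ccc(F)cc2)C(C)(C)CCC1n1ccnc1` gives 3890 nM in a functional assay on LNCaP cells (Homo sapiens) for inhibition, read by MTT assay (on this read-out lower numbers stand for stronger inhibition of growth and higher numbers for weaker inhibition of growth), the higher of the two numbers shown so far, though its step from compound 1 `CC1=C(/C=C/C(C)=C/C=C/C(C)=C\C(=O)Nc2ccc(O)cc2)C(C)(C)CCC1n1ccnc1`, which gives 3540 nM, is small: a 1.1-fold higher number from compound 1 to compound 2 (0.04 log units; within the scatter). Compound 3 `CC1=C(/C=C/C(C)=C/C=C/C(C)=C\C(=O)NCc2ccc(O)cc2)C(C)(C)CCC1n1ccnc1` differs from compound 2 by 4-hydroxybenzyl in place of 4-fluorophenyl on an amide-type nitrogen. Among the compounds with values here, only that one step bears on the change, and it concerned the ring substituent alone, fluoro against hydroxy; no measured pair shows the inserted carbon. The expected step is therefore a 1.1-fold lower number from compound 2 to compound 3 (0.05 log units; within the scatter), nothing beyond the scatter. Compound 3 is estimated at 3500 nM, ranging from 1200 nM to 10000 nM.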

Compound 3, concentration for 50% growth inhibition: 1690 nM
Compound 3: the middle estimate sits 2.1-fold (0.32 log units) above what was measured; low and high end bracket the measured number.
By their numbers in this assay, from the lowest: compound 3; then compounds 1 and 2 (each within the scatter of the next).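

In this assay, this amide-type nitrogen shows its first step beyond the scatter: with the ring hydroxy kept, 4-hydroxybenzyl in place of 4-hydroxyphenyl gives a modest gain (a 2.1-fold lower number from compound 1 to compound 3 (0.32 log units; beyond the scatter)). Measured against the fluoro anilide, the change is also modest and beyond the scatter (a 2.3-fold lower number from compound 2 to compound 3 (0.36 log units; beyond the scatter)), whereas swapping fluoro for hydroxy on the anilide ring alone had not left it. Nothing at hand explains this shift. Open, on these data alone, is whether 4-fluorobenzyl would match 4-hydroxybenzyl at this nitrogen, and whether a longer chain such as 2-phenylethyl would lower the number further.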